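The source may hold more compounds than are shown below. What is called first, only, known or untested is meant among the compounds shown, and "the series" means these compounds.

Measured compounds:
compound 1 `CCCCc1cc2ccccc2nc1-c1cc(-c2ccccc2)no1` with > 100000 nM (a limit of the assay);
compound 2 `CCc1cc2ccccc2nc1-c1cc(-c2ccc(C(F)(F)F)cc2)no1` with > 100000 nM (a limit of the assay);
compound 3 `CCCc1cc2ccccc2nc1-c1cc(-c2ccc(C(F)(F)F)cc2)no1` with 36500 nM.

Going by the values given here, compound 3 is the only compound of the three with a number in a functional assay on MDA-MB-231 cells (Homo sapiens) for inhibition, read by MTT assay, with a stated time of 24 h; on this read-out lower numbers stand for stronger inhibition and higher numbers for weaker inhibition; the other two sit at the limit of > 100000 nM in this assay, at which 2 of the 3 values shown sit. Compound 1 gives a limit in this assay. Compound 2 also gives a limit in this assay. Among the compounds with values here, compound 3 therefore stands alone as the one compound with a measured half-maximal inhibitory concentration.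

Compound 4 `CCCCc1cc2ccccc2nc1-c1cc(-c2ccc(C(F)(F)F)cc2)no1` has not been measured. It differs from compound 3 by methyl in place of hydrogen on a saturated chain carbon, three bonds along the chain from an aromatic carbon. Within the data shown here, the one measured step that resembles this change is an at least 2.7-fold lower number from compound 2 to compound 3 (0.43 log units; beyond the scatter), where the chain was lengthened by the same kind of addition one bond closer to the aromatic carbon. That step was beyond the scatter, though its size is only known as a limit because compound 2 gave no number. Whether a further lengthening continues in the same direction cannot be read from the three compounds; compound 1, which carries the butyl chain but lacks the trifluoromethyl group, gives a limit.

Compound 4 is therefore expected to give 25000 nM in this assay, within 8000 nM to 100000 nM, an expected step of a 1.5-fold lower number from compound 3 to compound 4 (0.16 log units; within the scatter).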

Compound 4, half-maximal inhibitory concentration: 10400 nM
Beside the measured number, compound 4's estimate is 2.4-fold (0.38 log units) above it; low and high end bracket the measured number.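

In this assay, the chain position three bonds along from an aromatic carbon still responds to methyl in place of hydrogen: the change from propyl to butyl gives a 3.5-fold lower number from compound 3 to compound 4 (0.55 log units; beyond the scatter), so the lengthening seen one bond closer continues in the same direction among compound 2, compound 3 and compound 4. Taken as a whole, ethyl in place of hydrogen on the saturated chain carbon two bonds along the chain from an aromatic carbon gives an at least 9.6-fold lower number from compound 2 to compound 4 (0.98 log units; beyond the scatter), which makes butyl the longest and the best-reading chain of the three that carry trifluoromethyl. Going by these compounds alone, the butyl chain alone does not produce a number, since trifluoromethyl in place of hydrogen on an aromatic carbon gives an at least 9.6-fold lower number from compound 1 to compound 4 (0.98 log units; beyond the scatter), the first comparison in which the chain stays fixed and only this group changes.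

On these data alone, whether a pentyl chain, a hexyl chain or a branched chain such as isobutyl would lower the number further remains open. Also open are whether a methoxy group could stand in place of trifluoromethyl and how large the steps from compound 1 and compound 2 really are: the limit of > 100000 nM in this assay, at which 2 of the 4 values shown sit.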